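The source may report more compounds than this note shows. Statements on the series, on what has been measured and on what is new or still open speak of the compounds shown alone.

Measured compounds:
compound 1 `O=C(NO)c1ccc(Cn2nnc(Cc3ccccc3)n2)cc1` gives 52 nM in an assay on Sf9 cells for inhibition of protein deacetylase HDAC6 (Homo sapiens), read by fluorescence; a higher number here means a weaker inhibitor, a lower number a stronger inhibitor
compound 2 `NCc1ccc(C(=O)NO)cc1` gives 695 nM in this assay

Compound 1 stands lowest of the two numbers, and its nearest neighbour, compound 2, lies a good way higher, a gap beyond the usual scatter of repeated measurements. Compound 3 `Nc1ccc(-c2nnn(Cc3ccc(C(=O)NO)cc3)n2)cc1` has not yet been measured. It differs from compound 1 in one place: 4-aminophenyl in place of benzyl on an aromatic carbon. The count of heavy atoms is unchanged, but the entering group brings one hydrogen-bond donor and one hydrogen-bond acceptor where the leaving group had none. For the measured compounds named here, no step between measured compounds shows what such an exchange does in this assay, so the expectation rests on compound 1 alone. A step from compound 1 to compound 3 of a 1.5-fold higher number from compound 1 to compound 3 (0.19 log units; within the scatter) is expected, small and not clearly beyond the scatter. Compound 3 is therefore estimated at 80 nM, within a range from 25 nM to 250 nM.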

Compound 3, half-maximal inhibitory concentration: 1 nM
For compound 3 the middle estimate is 80-fold (1.90 log units) above the measured one, and the stated range ends above it.
By their numbers in this assay, from the lowest: compound 3; then compound 1; then compound 2.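

In this assay, putting 4-aminophenyl in place of benzyl on the aromatic carbon of the five-membered ring gives a 52-fold lower number from compound 1 to compound 3 (1.72 log units; beyond the scatter), a large step and the first sign that this position strongly affects the number. The two groups have the same count of heavy atoms, so that count alone does not set the result; they differ in the amine and in how their six-membered ring is attached, since benzyl has a carbon link and 4-aminophenyl has none. Nothing available here explains why the exchange has so large an effect.

For the compounds shown here, the single step cannot show whether the amine, the loss of the carbon link or both lie behind it. Plain phenyl and 4-aminobenzyl at this position would separate those two changes.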